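This account rests on a few compounds, and the source may have more. Where it says the series, first, only, none or still open, it means among the compounds named here.

Of the compounds shown here, three sharing one core have been tested in a functional assay on the whole organism (6C3HED cells, Mus musculus) for inhibition, at a dose of 150 mg/kg by the oral route; a higher number here means more inhibition at the dose given (going by the name of the read-out), a lower number less inhibition. Compound 1 `O=C(Nc1ccc(Cl)cc1)NS(=O)(=O)c1ccc(Cl)s1` gives 58%, compound 2 `CCc1ccc(S(=O)(=O)NC(=O)Nc2ccc(Cl)cc2)o1` gives 57%, and compound 3 `CCc1csc(S(=O)(=O)NC(=O)Nc2ccc(Cl)cc2)c1` gives 55%. Compound 3 thus holds the lowest of the three numbers, yet all three sit within the usual scatter of one another, as the steps of a number 1 percentage points lower from compound 1 to compound 2 (within the scatter), a number 3 percentage points lower from compound 1 to compound 3 (within the scatter) and a number 2 percentage points lower from compound 2 to compound 3 (within the scatter) show. Compound 4 `COc1csc(S(=O)(=O)NC(=O)Nc2ccc(Cl)cc2)c1` differs from compound 3 in one place: methoxy in place of ethyl on an aromatic carbon. Within the data shown here, no measured step trades ethyl for methoxy; each measured step exchanges the whole ring on the sulfonyl sulfur, and each stayed within the scatter. The expectation for compound 4 is therefore a step of a number 1 percentage points lower from compound 3 to compound 4 (within the scatter), within the scatter. Compound 4 is estimated at 54%, expected to fall between 40% and 67%.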

Compound 4, a percentage reported as inhibition, in the whole organism at one dose (the size of the read-out at that dose, not a potency): 36%
Beside the measured number, compound 4's estimate is 18 percentage points above it; the whole stated range lies above it.
By their numbers in this assay, from the lowest: compound 4; then compounds 3, 2 and 1 (each within the scatter of the next).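

In this assay, methoxy in place of ethyl on this ring carbon, two ring bonds from the ring sulfur, gives a number 19 percentage points lower from compound 3 to compound 4 (beyond the scatter) even though the heavy-atom count stays the same. The wider comparisons agree, with a number 21 percentage points lower from compound 2 to compound 4 (beyond the scatter) and a number 22 percentage points lower from compound 1 to compound 4 (beyond the scatter) while the earlier ring exchanges all stayed within the scatter. So this position does respond to a small change, and one that replaces a carbon with an oxygen.

From the compounds shown here alone, whether an amine or a longer chain such as propyl at this carbon would also lower the number remains open. Nothing measured here explains the drop.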